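This account rests on a few compounds, and the source may have more. Where it says the series, first, only, none or still open, it means among the compounds named here.

Compound 1, `C/C(=C\CC/C(C)=C/CC[C@@H]1[C@@]2(C)CCC(=O)C(C)(C)[C@H]2CC[C@@]1(C)O)CC/C=C(\C)C(=O)OCc1cn(-c2ccccc2Cl)nn1`: in a functional assay on MDA-MB-231 cells (Homo sapiens) for antiproliferative activity, read by MTT assay, with a stated time of 48 h (a lower number here means a stronger inhibitor, a higher number a weaker inhibitor), compound 1 reaches only the limit > 150000 nM.
Compound 2, `C/C(=C\CC/C(C)=C/CC[C@@H]1[C@@]2(C)CCC(=O)C(C)(C)[C@H]2CC[C@@]1(C)O)CC/C=C(\C)C(=O)OCc1cn(-c2ccccc2C)nn1`: in this assay compound 2 reaches only the limit > 150000 nM.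
Compound 3, `C/C(=C\CC/C(C)=C/CC[C@@H]1[C@@]2(C)CCC(=O)C(C)(C)[C@H]2CC[C@@]1(C)O)CC/C=C(\C)C(=O)OCc1cn(-c2ccccc2C(F)(F)F)nn1`: in this assay compound 3 reaches only the limit > 150000 nM.

Compound 3 thus stands where every measured compound stands, at a limit rather than a number (the limit of > 150000 nM in this assay, at which 3 of the 3 values shown sit). Compound 4, `C/C(=C\CC/C(C)=C/CC[C@@H]1[C@@]2(C)CCC(=O)C(C)(C)[C@H]2CC[C@@]1(C)O)CC/C=C(\C)C(=O)OCc1cn(-c2ccccc2)nn1`, differs from compound 3 by hydrogen in place of trifluoromethyl on an aromatic carbon. Going by the values given here, the steps that bear on this exchange are a step that the two limits leave unreadable from compound 1 to compound 3, a step that the two limits leave unreadable from compound 2 to compound 3 and a step that the two limits leave unreadable from compound 1 to compound 2, none of which can be read because both ends sit at the limit (the limit of > 150000 nM in this assay, at which 3 of the 3 values shown sit). Nothing measured here shows that any group on that aromatic carbon changes the outcome in this assay, so the step that the limit leaves unreadable from compound 3 to compound 4 is expected to stay within the scatter, most likely as another limit. Compound 4 is therefore estimated at 200000 nM, in the range 100000 nM to 400000 nM.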

Compound 4, half-maximal inhibitory concentration: > 150000 nM
Compound 4 gave a limit, no number (the forecaster's own chance of this, stated with the estimate: 85%); the middle value is on the limit's open side.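

Compound 4 also gives only a limit, so none of its steps to compound 1, compound 2 or compound 3 can be read: the limit of > 150000 nM in this assay, at which 4 of the 4 values shown sit.

The compounds shown leave open whether any change to this structure would give an actual number in this assay.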